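Shortening a dialkylamino group and cell toxicity

The source may report more compounds than this note shows. Statements on the series, on what has been measured and on what is new or still open speak of the compounds shown alone.

Compound 1 `CCCN(CCC)c1cc2[nH]c(C3CCCCC3)nc2cc1NC(=O)c1ccccc1` in an ADME assay on Vero cells (Chlorocebus sabaeus) for cytotoxicity, read by resazurin assay, with a stated time of 3 days; a higher number here means a weaker inhibitor, a lower number a stronger inhibitor: > 100 ug/mL, a limit of the assay.
Compound 2 `CCCCOC(=O)Nc1cc2nc(C3CCCCC3)[nH]c2cc1N(CCC)CCC` in this assay: > 100 ug/mL, a limit of the assay.
Compound 3 `CCCOCC(=O)Nc1cc2nc(C3CCCCC3)[nH]c2cc1N1CCCC1` in this assay: > 100 ug/mL, a limit of the assay.

Compound 1 stands only at a limit in this assay. On these data alone, its value is not a number but the edge of what the assay can report, so its true position is unknown beyond that edge. Going by the values given here, the only step between measured compounds that differ in one place, a step that the two limits leave unreadable from compound 1 to compound 2, cannot be read either, since both ends of it are limits; the amide is changed there, not the amino group.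

Compound 4 `CN(C)c1cc2[nH]c(C3CCCCC3)nc2cc1NC(=O)c1ccccc1` differs from compound 1 in another place: dimethylamino in place of dipropylamino on an aromatic carbon. Among the compounds with values here, no measured step touches this amino group, so nothing directly bears on the change. What the data do show is the limit of > 100 ug/mL in this assay, at which 3 of the 3 values shown sit, which means every compound of this series examined so far is too weak an inhibitor of cell growth to be placed on the scale.

On that basis compound 4 is expected to sit at the same edge, with an estimated step that the limit leaves unreadable from compound 1 to compound 4, meaning no readable change. The estimate for compound 4 is therefore 150 ug/mL, between 50 ug/mL and 500 ug/mL, most likely reported again only as a limit.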

Compound 4, half-maximal inhibitory concentration: > 100 ug/mL
Compound 4: only a limit was reported (the forecaster's own chance of this, stated with the estimate: 80%); the middle value lies beyond the limit too.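

Compound 1 and compound 4 are both reported only as limits in this assay, so the change from dipropylamino to dimethylamino cannot be read as a step. All the compounds share that edge: the limit of > 100 ug/mL in this assay, at which 4 of the 4 values shown sit.

The compounds shown leave open how far each lies beyond the limit, and whether shortening the amino group alters cell toxicity at all.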